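Replacing Cyano with Chloro: Compound 1 to Compound 4

The compounds below may be only part of what the source reports. "The series", "measured", "known", "first", "only" and "open" are said of these compounds alone.

Compound 1 `CCOc1ccc(Br)cc1-c1cc(Nc2ccc(C#N)cc2)nc(N)n1`: 70 nM
Compound 2 `Cc1ccc(F)cc1-c1cc(Nc2ccc(Cl)cc2)nc(N)n1`: 250 nM
Compound 3 `Cc1ccc(Cl)cc1-c1cc(Nc2cccc(Br)c2)nc(N)n1`: 200 nM

In a functional assay on K562 cells (Homo sapiens) for inhibition (a lower number here means a stronger inhibitor, a higher number a weaker inhibitor), compound 1 gives 70 nM, the lowest number of the three and clearly apart from the others. Compound 3 gives 200 nM and compound 2 gives 250 nM, and these two values lie within the scatter of each other.

The next compound to be tested is compound 4 `CCOc1ccc(Br)cc1-c1cc(Nc2ccc(Cl)cc2)nc(N)n1`, which keeps the core of compound 1 but has chloro in place of cyano on an aromatic carbon, turning the 4-cyanophenyl into 4-chlorophenyl (chloro in place of cyano on an aromatic carbon). For the measured compounds named here, no measured pair isolates this change. Compound 2 also carries a 4-chlorophenyl and gives 250 nM, but the rest of its structure differs from that of compound 1, so it is only a loose guide. A moderate weakening is therefore expected, shown by the estimated step of a 2.3-fold higher number from compound 1 to compound 4 (0.36 log units; beyond the scatter). Compound 4 is estimated at 160 nM, with an expected range of 60 nM to 420 nM.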

Compound 4, half-maximal inhibitory concentration: 50 nM
Compound 4: the middle estimate sits 3.2-fold (0.51 log units) above what was measured, and the stated range ends above it.
By their numbers in this assay, from the lowest: compounds 4 and 1 (each within the scatter of the next); then compounds 3 and 2 (each within the scatter of the next).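

In this assay the exchange of 4-cyanophenyl for 4-chlorophenyl gives a 1.4-fold lower number from compound 1 to compound 4 (0.15 log units; within the scatter) and this step lies within the scatter, so the two groups cannot be told apart at this position on the core of compound 1. The exchange replaces two heavy atoms with one and removes a triple bond and a hydrogen-bond acceptor, yet compound 1 and compound 4 still read alike. For the compounds shown here, this is the first comparison that isolates a single place, which the earlier compounds, differing in several places, could not provide. Nothing available explains why the two groups read alike.

From the compounds shown here alone, whether an amine or a carboxylic acid at this position would also read alike remains open. Going by these compounds, it is equally open whether chloro and cyano stay indistinguishable when the ethoxy or bromo groups of the core are replaced.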